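Swapping the acyl group on compound 3

This account rests on a few compounds, and the source may have more. Where it says the series, first, only, none or still open, it means among the compounds named here.

Measured so far in a functional assay on SU-DHL-6 cells (Homo sapiens) for antiproliferative activity, read by MTT assay; a higher number here means a weaker inhibitor, a lower number a stronger inhibitor:
compound 1 `COc1ncc(-c2ccc3ncnc(N[C@H]4CCCN(C(=O)C(F)(F)F)C4)c3c2)cc1C#N` gives 210 nM
compound 2 `COc1ncc(-c2ccc3ncnc(N[C@H]4CCCN(C(=O)C5CCOCC5)C4)c3c2)cc1C#N` gives 150 nM
compound 3 `COc1ncc(-c2ccc3ncnc(N[C@H]4CCCN(C(=O)c5cccnc5)C4)c3c2)cc1C#N` gives 120 nM

In this assay compound 3 gives 120 nM, within the scatter of both other compounds. Compound 4 `COc1ncc(-c2ccc3ncnc(N[C@H]4CCCN(C(=O)C(C)N)C4)c3c2)cc1C#N` carries 1-aminoethyl in place of pyridin-3-yl on a carbonyl carbon. Three measured steps change this same group: a 1.4-fold lower number from compound 1 to compound 2 (0.15 log units; within the scatter), a 1.8-fold lower number from compound 1 to compound 3 (0.24 log units; within the scatter) and a 1.3-fold lower number from compound 2 to compound 3 (0.10 log units; within the scatter). For the measured compounds named here, all three stay within the scatter, although no measured compound carries 1-aminoethyl. No step beyond the scatter is therefore expected, and the estimated step is a 1.3-fold higher number from compound 3 to compound 4 (0.10 log units; within the scatter). For compound 4 the expected value is 150 nM, with an estimated range of 60 nM to 380 nM.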

Compound 4, half-maximal inhibitory concentration: 440 nM
The estimate for compound 4 lay 2.9-fold (0.47 log units) below the measured number; the measured number lies above the stated range.
By their numbers in this assay, from the lowest: compounds 3, 2 and 1 (each within the scatter of the next); then compound 4.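

In this assay, for the compounds shown here, the acyl position had looked indifferent to the group on the carbonyl carbon, but 1-aminoethyl is the first change to pass the scatter, giving a weaker inhibitor against all three earlier groups (a 3.7-fold higher number from compound 3 to compound 4 (0.56 log units; beyond the scatter); a 2.9-fold higher number from compound 2 to compound 4 (0.47 log units; beyond the scatter); a 2.1-fold higher number from compound 1 to compound 4 (0.32 log units; beyond the scatter)). The position therefore does respond to its substituent, though each step is modest. Nothing measured here bears on the reason for this.

The compounds shown leave open whether the shift follows the amine or the short open chain. A hydroxyl in place of that amine, or a longer chain ending in an amine, would separate the two.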